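Mirror Image of the Trifluoromethyl Carbamate: Compound 3

The source may report more compounds than this note shows. Statements on the series, on what has been measured and on what is new or still open speak of the compounds shown alone.

Measured compounds:
compound 1 `Cc1nc(S(C)(=O)=O)ccc1Oc1ncnc(OC2CCN(C(=O)OC(C)F)CC2)c1F`: 315 nM
compound 2 `Cc1nc(S(C)(=O)=O)ccc1Oc1ncnc(OC2CCN(C(=O)O[C@H](C)C(F)(F)F)CC2)c1F`: 110 nM

In a functional assay on isolated protein for inhibition of Glucose-dependent insulinotropic receptor (Rattus norvegicus), read by HTRF and cAMP accumulation (a higher number here means that more compound is needed for the effect, a lower number that less compound is needed), compound 2 holds the lowest of the two numbers; its nearest neighbour is compound 1, with a step of a 2.9-fold lower number from compound 1 to compound 2 (0.46 log units; beyond the scatter). Within the data shown here, that is the only measured step, and it swaps one group for another on the carbamate oxygen, changing atoms rather than configuration.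

Compound 3 `Cc1nc(S(C)(=O)=O)ccc1Oc1ncnc(OC2CCN(C(=O)O[C@@H](C)C(F)(F)F)CC2)c1F` is the mirror counterpart of compound 2: the two compounds have the same atoms and bonds and differ only in configuration as drawn: 1 of 1 stereo elements differ; a stereocentre at a saturated chain carbon is drawn R in compound 2 and S in compound 3. Among the measured compounds shown here, no measured step bears on a change of configuration alone, so the expected size of the step in this assay cannot be taken from the data. The measured step of a 2.9-fold lower number from compound 1 to compound 2 (0.46 log units; beyond the scatter) shows only that this part of the molecule is read by the assay, which makes a difference between the two configurations plausible in either direction. Compound 3 is therefore estimated at 250 nM, with a wide range from 70 nM to 1200 nM, which corresponds to an expected step of a 2.3-fold higher number from compound 2 to compound 3 (0.36 log units; beyond the scatter).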

Compound 3, half-maximal effective concentration: 109 nM
Estimate against measurement, compound 3: 2.3-fold (0.36 log units) above, and the stated range covers the measured number.
By their numbers in this assay, from the lowest: compounds 3 and 2 (each within the scatter of the next); then compound 1.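

In this assay, swapping the drawn configuration at the saturated chain carbon of the 1-(trifluoromethyl)ethyl group leaves the read-out within the scatter, with a 1.0-fold lower number from compound 2 to compound 3 (0.00 log units; within the scatter). The advantage of this group over 1-fluoroethyl on the oxygen next to a carbonyl group therefore does not depend on one drawn configuration: a 2.9-fold lower number from compound 1 to compound 3 (0.46 log units; beyond the scatter) has the same size as a 2.9-fold lower number from compound 1 to compound 2 (0.46 log units; beyond the scatter). This comparison isolates the stereocentre, as no other structural change accompanies it, which is shown by this fact: the fact that compounds 2 and 3 differ only in the configuration as drawn

The compounds shown leave open how the assay reads other groups on this oxygen, such as a tert-butyl or a cyclopropyl group, and whether a group of that kind would also show no separation between configurations where it carries a stereocentre. They also leave open whether the match between the two configurations would persist on the receptor of another species, or if the methylsulfonyl group on the shared core were replaced by a nitrile.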